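The source may report more compounds than this note shows. Statements on the series, on what has been measured and on what is new or still open speak of the compounds shown alone.

Measured so far in a functional assay on the whole organism (strain Wistar albino) for inhibition, with Rattus norvegicus as the target, read by paw edema, with a stated time of 1 h, at a dose of 100 mg/kg by the oral route; on this read-out lower numbers stand for less inhibition and higher numbers for more inhibition at the one dose given (going by the name of the read-out):

compound 1, `Cc1ccc2c(Cc3nn4cc(-c5ccc(Cl)cc5)nc4s3)coc2c1`: 13.4%
compound 2, `Cc1ccc2c(Cc3nn4c(C=O)c(-c5ccc(Cl)cc5)nc4s3)coc2c1`: 11.4%
compound 3, `Cc1ccc2c(Cc3nn4c(C=O)c(-c5ccc(Br)cc5)nc4s3)coc2c1`: 12.4%

All three numbers fall within the usual scatter of one another. The step from the unsubstituted core to the formyl compound is a number 2 percentage points lower from compound 1 to compound 2 (within the scatter), and the halogen exchange on the pendant phenyl gives a number 1 percentage points higher from compound 2 to compound 3 (within the scatter). Among the measured compounds shown here, compound 2 therefore cannot be separated from compound 1 or compound 3 on the paw-edema read-out; the series so far shows a flat response at the dose given.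

Compound 4, `Cc1ccc2c(Cc3nn4c(CO)c(-c5ccc(Cl)cc5)nc4s3)coc2c1`, has not been measured. Relative to compound 2 the change is hydroxymethyl in place of formyl on an aromatic carbon. For the measured compounds named here, the one measured step that touches the same position is the one from compound 1 to compound 2, where placing formyl on that carbon moved the read-out only within the scatter. The bromo-for-chloro step sits elsewhere and says nothing about this carbon. On that basis no step beyond the scatter is expected in this assay for compound 4, in either direction; the estimated step is a number 1.6 percentage points higher from compound 2 to compound 4 (within the scatter). The expected value for compound 4 is 13%, with a range from 5% to 22%.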

Compound 4, a percentage reported as inhibition, in the whole organism at one dose (the size of the read-out at that dose, not a potency): 14.5%
Estimate against measurement, compound 4: 1.5 percentage points below; measured number inside the range.
By their numbers in this assay, from the lowest: compounds 2, 3, 1 and 4 (each within the scatter of the next).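

Read in this assay the exchange of formyl for hydroxymethyl on this carbon of the five-membered aromatic ring (a number 3.1 percentage points higher from compound 2 to compound 4 (within the scatter)) brings in a hydrogen-bond donor where formyl has none, and the read-out does not separate the two groups. Among the compounds shown here, the same carbon can now also be compared between hydrogen and hydroxymethyl (a number 1.1 percentage points higher from compound 1 to compound 4 (within the scatter)), so hydrogen, formyl and hydroxymethyl at this position all lie within the scatter of one another, a wider basis for the flat response than the single formyl step gave. Nothing measured here offers an explanation for this flat response.

Whether this position stays flat with a carboxylic acid, an aminomethyl group or a longer alkyl chain remains open, since the three groups shown are all small and leave the read-out low at the one dose and time given. Also open, on these data alone, is whether hydroxymethyl behaves the same way with bromo in place of chloro on the pendant phenyl, and whether any separation between these compounds would appear at another dose.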